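Amide series at a serotonin receptor: note on compound 4

A few compounds are considered here, and "the series" means these few. Any claim that something is new, unique, unknown or untested is made for them only; others in the source may bear on it.

Three amides carry the shared core. Compound 1 `CN1CCC(c2c[nH]c3ccc(NC(=O)C4CCCCC4)nc23)CC1` gives 20 nM in an assay for binding affinity to 5-hydroxytryptamine receptor 1F (Homo sapiens), read by radioligand binding; on this read-out lower numbers stand for stronger inhibition and higher numbers for weaker inhibition. Compound 2 `CCN1CC=C(c2c[nH]c3ccc(NC(=O)c4ccc(F)cc4)nc23)CC1` gives 25 nM in this assay, and compound 3 `CCN1CC=C(c2c[nH]c3ccc(NC(C)=O)nc23)CC1` gives 21 nM. Among the compounds with values here, compound 2 stands with the highest of the three numbers, but both neighbours sit within the scatter of it: the one measured single-point step, a 1.2-fold lower number from compound 2 to compound 3 (0.08 log units; within the scatter), shows that exchanging the amide substituent leaves the read-out essentially unchanged, and compound 1 lies similarly close.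

Compound 4 `O=C(Nc1ccc2[nH]cc(C3CCNCC3)c2n1)c1ccc(F)cc1` is yet to be measured in this assay. Relative to compound 2 the change is a group of 6 heavy atoms (5 carbon, 1 nitrogen; one six-membered non-aromatic ring with 1 hetero atom) in place of a group of 8 heavy atoms (7 carbon, 1 nitrogen; one six-membered non-aromatic ring with 1 hetero atom), on an aromatic carbon. Within the data shown here, no measured step covers this change: compound 1 carries a piperidin-4-yl bearing a methyl on its nitrogen, but it differs from compound 2 at the amide as well, so it can be set beside compound 2 without a computed step, only through the value of compound 1, 20 nM. Both being close, the expected step is no change at the digits printed from compound 2 to compound 4 (within the scatter), none beyond the scatter. Compound 4 is therefore estimated at 25 nM, within a range of 8 nM to 80 nM.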

Compound 4, inhibition constant: 9.5 nM
Estimate against measurement, compound 4: 2.6-fold (0.42 log units) above; the measured number falls inside the stated range.
By their numbers in this assay, from the lowest: compound 4; then compounds 1, 3 and 2 (each within the scatter of the next).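

In this assay, the group on the aromatic carbon of the five-membered ring moves the number where the amide substituent did not: this change gives a 2.6-fold lower number from compound 2 to compound 4 (0.42 log units; beyond the scatter), whereas the amide exchange gives a 1.2-fold lower number from compound 2 to compound 3 (0.08 log units; within the scatter). The step bundles several differences: the entering piperidin-4-yl has 6 heavy atoms, 1 hydrogen-bond donor and no double bond outside aromatic rings, while the leaving group has 8 heavy atoms, 0 hydrogen-bond donors and 1 such double bond. Nothing at hand explains the step.

Which of these differences carries the step remains open. A piperidin-4-yl bearing an ethyl on its nitrogen, set on the amide of compound 4, would separate the ring double bond from the nitrogen substituent, and a propyl on that nitrogen would test chain length.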